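Compound 2 to compound 3: losing the ester-bearing aryl

The source may report more compounds than this note shows. Statements on the series, on what has been measured and on what is new or still open speak of the compounds shown alone.

Compound 1 `COc1cc(Nc2ncnc3c(NC(=O)Nc4ccc(C)c(C)c4)cccc23)cc(OC)c1`: 8.8 nM
Compound 2 `CCOC(=O)c1ccc(NC(=O)Nc2cccc3c(Nc4cc(OC)cc(OC)c4)ncnc23)cc1`: 317 nM

In a functional assay on RT-112 cells (Homo sapiens) for antiproliferative activity, read by MTT assay, with a stated time of 72 h (a higher number here means a weaker inhibitor of growth, a lower number a stronger inhibitor of growth), compound 2 has the higher number of the two, at 317 nM. The next structure is compound 3 `COc1cc(Nc2ncnc3c(NC(=O)c4ccc(CN(C)C)cc4)cccc23)cc(OC)c1`: 4-((dimethylamino)methyl)phenyl in place of (4-(ethoxycarbonyl)phenyl)amino on a carbonyl carbon. For the measured compounds named here, the only measured step bearing on this is a 36-fold higher number from compound 1 to compound 2 (1.56 log units; beyond the scatter), large and beyond the scatter, which brought in the 4-(ethoxycarbonyl)phenyl that compound 3 lacks. Going by the values given here, no measured compound carries the entering group, so a smaller move towards a lower number is expected, giving the estimated step of a 3.2-fold lower number from compound 2 to compound 3 (0.50 log units; beyond the scatter). The estimate for compound 3 is 100 nM, with an expected range of 20 nM to 500 nM.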

Compound 3, concentration for 50% growth inhibition: 4370 nM
Estimate against measurement, compound 3: 44-fold (1.64 log units) below; measured number above the stated range.
By their numbers in this assay, from the lowest: compound 1; then compound 2; then compound 3.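

On this carbonyl carbon, 4-((dimethylamino)methyl)phenyl in place of (4-(ethoxycarbonyl)phenyl)amino weakens growth inhibition in this assay, with a 14-fold higher number from compound 2 to compound 3 (1.14 log units; beyond the scatter). Against (3,4-dimethylphenyl)amino, the same replacement gives a 500-fold higher number from compound 1 to compound 3 (2.70 log units; beyond the scatter), so the ester-bearing group, although poorer than 3,4-dimethylphenyl, is still far better tolerated than the entering group. No measured evidence accounts for this loss.

The change removes the amide-type nitrogen and alters the aryl substituent together, leaving their contributions unseparated. As far as these compounds go, a (4-((dimethylamino)methyl)phenyl)amino group at this carbonyl carbon, or a carboxylic acid in place of the ethyl ester, remains open.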